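The source may hold more compounds than are shown below. What is called first, only, known or untested is meant among the compounds shown, and "the series" means these compounds.

Measured compounds:
compound 1 `Cc1cc(NCc2ccccn2)n2ncc(-c3ccc(F)cc3)c2n1`: < 5000 nM
compound 2 `Cc1cc(NCc2ccccn2)n2ncc(-c3ccc(F)c(Cl)c3)c2n1`: < 5000 nM

In a physicochemical assay for solubility, read by HPLC, using the shake flask method, measured as kinetic solubility, with a stated time of 2 h, at pH 7.4 (on this read-out lower numbers stand for lower solubility and higher numbers for higher solubility), compound 1 gives only a limit, < 5000 nM. Compound 2 likewise gives only a limit, < 5000 nM. The step that the two limits leave unreadable from compound 1 to compound 2 cannot be read, and the limit of < 5000 nM in this assay, at which 2 of the 2 values shown sit, describes where both values sit. Compound 3 `Cc1cc(NCc2ccccn2)n2ncc(-c3cc(F)c(F)c(F)c3)c2n1` carries 3,4,5-trifluorophenyl in place of 3-chloro-4-fluorophenyl on an aromatic carbon. Among the measured compounds shown here, no measured step bears on this change with a readable size. Compound 3 is expected to stay at the limit as well, so the estimated step that the limit leaves unreadable from compound 2 to compound 3 rests on no readable comparison. The estimate for compound 3 is 2000 nM, within 300 nM to 6000 nM.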

Compound 3, solubility: < 5000 nM
Compound 3 ended at the assay's limit (the forecaster's own chance of this, stated with the estimate: 80%); the middle value lies beyond the limit too.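

No step among compound 1, compound 2 and compound 3 can be read in this assay, since all three values are limits and not numbers: the limit of < 5000 nM in this assay, at which 3 of the 3 values shown sit.

On these data alone, the actual solubility of each compound stays open, as does whether either aromatic change alters it.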